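Para-fluoro and trifluoromethyl benzyl groups on a nucleoside core

This account rests on a few compounds, and the source may have more. Where it says the series, first, only, none or still open, it means among the compounds named here.

The measured compounds and their values in a functional assay on HOS cells (Homo sapiens) for antiproliferative activity, with a stated time of 72 h; a lower number here means a stronger inhibitor, a higher number a weaker inhibitor:

Compound 1 `OC[C@H]1O[C@@H](n2cnc3c(NCc4cccc(F)c4)ncnc32)[C@H](O)[C@@H]1O` gives > 166000 nM, which is a limit of the assay rather than a number.
Compound 2 `OC[C@H]1O[C@@H](n2cnc3c(NCc4ccc(F)cc4)ncnc32)[C@H](O)[C@@H]1O` gives 13200 nM.
Compound 3 `OC[C@H]1O[C@@H](n2cnc3c(NCc4cc(O)cc(O)c4)ncnc32)[C@H](O)[C@@H]1O` gives > 166000 nM, again a limit of the assay and not a number.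

Compound 3 thus stands at the limit, with nothing more known than that; the limit of > 166000 nM in this assay, at which 2 of the 3 values shown sit, shows that it shares this position with one other compound. For the measured compounds named here, only the step of an at least 12-fold higher number from compound 2 to compound 3 (1.09 log units; beyond the scatter) can be read, and it is large. The step of an at least 12-fold lower number from compound 1 to compound 2 (1.09 log units; beyond the scatter) is also large. The step that the two limits leave unreadable from compound 1 to compound 3 cannot be read, as both ends are limits.

The next compound, compound 4 `OC[C@H]1O[C@@H](n2cnc3c(NCc4ccc(C(F)(F)F)cc4)ncnc32)[C@H](O)[C@@H]1O`, differs from compound 3 in one place: 4-(trifluoromethyl)phenyl in place of 3,5-dihydroxyphenyl on a saturated chain carbon bound to a nitrogen on an aromatic ring. The measured steps that bear on this are an at least 12-fold higher number from compound 2 to compound 3 (1.09 log units; beyond the scatter) and an at least 12-fold lower number from compound 1 to compound 2 (1.09 log units; beyond the scatter), both large. Compound 4 carries its single substituent at the same position of the phenyl ring as compound 2, so in this assay it is expected to move away from the limit by a step about as large as an at least 11-fold lower number from compound 3 to compound 4 (1.04 log units; beyond the scatter), toward the value of compound 2. Compound 4 is therefore estimated at 15000 nM, within a range from 3000 nM to 100000 nM.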

Compound 4, half-maximal inhibitory concentration: > 166000 nM
Compound 4: no number, only a limit (the forecaster's own chance of this, stated with the estimate: 20%); middle value at least 11-fold (1.04 log units) away from the limit.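

In this assay, trifluoromethyl in place of fluoro on an aromatic carbon gives an at least 12-fold higher number from compound 2 to compound 4 (1.09 log units; beyond the scatter). For the compounds shown here, this is the first direct comparison of two groups on the same benzyl framework with the ring otherwise unchanged, and it shows that the measurable activity of compound 2 does not extend to every such group: 4-fluorophenyl gives a number, while 4-(trifluoromethyl)phenyl does not. The result for compound 4 is a limit of the assay and not a number, so its steps to compound 1 and to compound 3 cannot be read and no order among these three can be stated, leaving compound 2 alone with a measured value: the limit of > 166000 nM in this assay, at which 3 of the 4 values shown sit.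

The compounds shown leave open whether other groups in place of fluoro on that aromatic carbon, such as a chlorine atom, a methoxy group or an amine, would give a number like that of compound 2 or would also stop at the limit. They also give no way to tell how far beyond the limit compound 1, compound 3 and compound 4 really lie, or why the fluoro compound alone gives a number.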